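The source may report more compounds than this note shows. Statements on the series, on what has been measured and on what is new or still open speak of the compounds shown alone.

Of the compounds shown here, two of a shared core have been tested in a functional assay on DLD-1 cells (Homo sapiens) for cytotoxicity, read by MTT assay, with a stated time of 72 h; on this read-out higher numbers stand for weaker inhibition and lower numbers for stronger inhibition. Compound 1 `Cc1c(/N=C/c2ccc(N(C)C)cc2)c(=O)n(-c2ccccc2)n1C` gives 871000000 nM. Compound 2 `Cc1c(/N=C/c2ccccc2Cl)c(=O)n(-c2ccccc2)n1C` gives 417000000 nM, and it stands as the lower of the two numbers, with compound 1 lying above it by a margin that exceeds the usual scatter of the assay. Compound 3 `Cc1c(/N=C/c2ccc(Cl)cc2)c(=O)n(-c2ccccc2)n1C` has not yet been measured in this assay. It differs from compound 2 in one place: 4-chlorophenyl in place of 2-chlorophenyl on a carbon with a double bond to nitrogen. The two compounds contain the same atoms, joined differently, so the change is a rearrangement rather than an addition or removal of any group. No measured step of this kind is available among the compounds shown, so the expected size of the step from compound 2 to compound 3 is taken to be a 1.2-fold higher number from compound 2 to compound 3 (0.08 log units; within the scatter), which is within the scatter and without a clear direction. Compound 3 is therefore estimated at 500000000 nM in this assay, with a range from 150000000 nM to 1600000000 nM.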

Compound 3, half-maximal inhibitory concentration: 631000000 nM
For compound 3 the middle estimate is 1.3-fold (0.10 log units) below the measured one, and the stated range covers the measured number.
By their numbers in this assay, from the lowest: compounds 2, 3 and 1 (each within the scatter of the next, the first and the last beyond it).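

In this assay, among the compounds shown here, 4-chlorophenyl in place of 2-chlorophenyl on a carbon with a double bond to nitrogen gives a 1.5-fold higher number from compound 2 to compound 3 (0.18 log units; within the scatter) and thus provides the first direct reading of this rearrangement: at this place, the two chlorophenyl groups cannot be told apart within the scatter. Chloro in place of dimethylamino on an aromatic carbon gives a 1.4-fold lower number from compound 1 to compound 3 (0.14 log units; within the scatter) and also stays within the scatter, so neither exchange separates the compounds in the pair it links. Nothing measured on these compounds accounts for either step.

The compounds shown leave open whether a different group at this place, such as a carboxylic acid, a primary amine or a methoxy group, would shift the number beyond the scatter. They also leave open whether a change on the shared core itself, such as a longer chain in place of a methyl group, would do so.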